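Trimming the Alkyne Substituent in a Vitamin D Receptor Series

The source may report more compounds than this note shows. Statements on the series, on what has been measured and on what is new or still open speak of the compounds shown alone.

Two measured compounds set the scene. Compound 1 `CCN(CC)CCNC(=O)C1CC(C(CC)(CC)c2ccc(C#CC(C)(O)CC)c(C)c2)=CN1CC` and compound 2 `CCN(CC)CCNC(=O)C1CC(C(CC)(CC)c2ccc(C#CC(O)C3CCC3)c(C)c2)=CN1CC` share the same core and differ only in the group on the triple-bonded carbon. In an assay on isolated protein for binding affinity to vitamin D3 receptor (Homo sapiens), read by fluorescence polarization, tested at 1 uM (on this read-out lower numbers stand for less inhibition and higher numbers for more inhibition at the one concentration tested (going by the name of the read-out)), compound 1 gives 59.2%, while compound 2 gives 49.3%. The step of a number 9.9 percentage points lower from compound 1 to compound 2 (within the scatter) is too small to count as a real change, so the two compounds are treated as equals here, although compound 2 holds the lower of the two numbers.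

Compound 3 `C#Cc1ccc(C(CC)(CC)C2=CN(CC)C(C(=O)NCCN(CC)CC)C2)cc1C` removes the substituent altogether: a hydrogen atom in place of a group of 6 heavy atoms (5 carbon, 1 oxygen; one four-membered non-aromatic ring of carbon only), on a triple-bonded carbon. For the measured compounds named here, no measured step matches this change. Going by the values given here, the only step on this position, a number 9.9 percentage points lower from compound 1 to compound 2 (within the scatter), exchanged one hydroxyl-bearing group for another of similar size and did not move the number beyond the scatter; it says nothing about taking the whole group away. Among the compounds with values here, with no comparable precedent, a modest loss is expected, so the step of a number 11.3 percentage points lower from compound 2 to compound 3 (beyond the scatter) is the estimate for this change. Compound 3 is therefore expected to give 38% in this assay, within a range from 18% to 58%.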

Compound 3, a percentage reported as inhibition, at one concentration (the size of the read-out at that concentration, not a potency): "not active" (no number reported)
The entry for compound 3 holds no number, and the estimate cannot be compared.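

In this assay, for the compounds shown here, compound 3 is recorded as "not active" without a number, so no step from compound 1 or compound 2 to compound 3 can be read. No other information bears on this result. The compounds shown leave open how much the numbers for compound 1 and compound 2 depend on having a hydroxyl-bearing group on the triple-bonded carbon.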